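Methoxy for trifluoromethyl on a second urotensin-2 core

This account rests on a few compounds, and the source may have more. Where it says the series, first, only, none or still open, it means among the compounds named here.

The series rests on three measured amides. Compound 2 `CN(C)CCC(NC(=O)CCc1ccc(C(F)(F)F)cc1)c1ccc2ccccc2c1` gives 372 nM in a functional assay on NIH3T3 cells for agonist activity at Urotensin-2 receptor (Homo sapiens), with a stated time of 5 days; on this read-out lower numbers stand for an effect already at smaller amounts and higher numbers for an effect only at larger amounts of compound. Compound 1 `COc1ccc(CCC(=O)NC(CCN(C)C)c2ccc3ccccc3c2)cc1` differs from it by methoxy in place of trifluoromethyl on an aromatic carbon and gives 1410 nM, a step of a 3.8-fold higher number from compound 2 to compound 1 (0.58 log units; beyond the scatter). Compound 3 `CN(C)CCC(NC(=O)CCc1ccc(C(F)(F)F)cc1)c1ccc(Cl)cc1` carries a different core, described by 4-chlorophenyl in place of naphthalen-2-yl on a saturated chain carbon bound to an amide-type nitrogen and a saturated chain carbon, and gives 1120 nM in this assay; that step is a 3.0-fold higher number from compound 2 to compound 3 (0.48 log units; beyond the scatter). The values of compound 1 and compound 3 lie within the scatter of each other, so nothing separates them.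

Compound 4 `COc1ccc(CCC(=O)NC(CCN(C)C)c2ccc(Cl)cc2)cc1` has not been measured. It differs from compound 3 by methoxy in place of trifluoromethyl on an aromatic carbon. The place is the same as in the change from compound 2 to compound 1, so this is the same change, made on the core of compound 3 instead of the core of compound 2. Since that change raised the number by a 3.8-fold higher number from compound 2 to compound 1 (0.58 log units; beyond the scatter), the expected step here is a 3.6-fold higher number from compound 3 to compound 4 (0.55 log units; beyond the scatter), which in this assay puts compound 4 at an estimated 4000 nM, with an expected range from 1500 nM to 12000 nM. A weaker number than that of compound 3 is expected, because compound 3 starts at 1120 nM.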

Compound 4, half-maximal effective concentration: 2950 nM
Compound 4: the middle estimate sits 1.4-fold (0.13 log units) above what was measured; low and high end bracket the measured number.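

On the second core, methoxy in place of trifluoromethyl gives a 2.6-fold higher number from compound 3 to compound 4 (0.42 log units; beyond the scatter) in this assay and so moves the number the same way as on the first core. The change therefore carries over between these two cores, in direction and, within the scatter, in size: the same change on two cores in this assay, a 3.8-fold higher number (0.58 log units; beyond the scatter) from compound 2 to compound 1 and a 2.6-fold higher number (0.42 log units; beyond the scatter) from compound 3 to compound 4, 1.4-fold (0.16 log units) apart, within the scatter of two such steps. This rests on just two matched pairs, so it shows agreement for these two cores only; it does not show that the step would hold on any other core, and it does not explain why methoxy gives the higher number on either one.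

The compounds shown leave open whether other groups at the same aromatic carbon, such as a nitrile, a hydroxyl or a plain chlorine, would behave alike on both cores. They also leave open how a longer chain carrying the amide, or a primary amine in place of the dimethylamino group, would alter the number in this assay on either core.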